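Bromo in place of cyclopropyloxy on the shared core

The source may report more compounds than this note shows. Statements on the series, on what has been measured and on what is new or still open speak of the compounds shown alone.

Compound 2 `CC(Oc1ccccc1OC1CC1)C1=NCCN1` gives 0.6 in an assay on CHO cells with Alpha-2B adrenergic receptor (Homo sapiens) as the target; a higher number here means a larger maximal response, a lower number a smaller maximal response. Among the three numbers this is the second highest: compound 1 `C=CCc1cccc(CC=C)c1OC(C)C1=NCCN1` gives 0.65 in this assay, within the scatter of compound 2, while compound 3 `C=C(C)c1ccccc1OC(C)C1=NCCN1` gives 0.4, beyond it. For the measured compounds named here, the one measured step from the same parent, a number 0.20 lower from compound 2 to compound 3 (beyond the scatter), is modest. Compound 4 `CC(Oc1ccccc1Br)C1=NCCN1` differs from compound 2 in one place: bromo in place of cyclopropyloxy on an aromatic carbon. Going by the values given here, only that step bears on the change, and it concerns a different entering group, so in this assay a downward move of roughly the scatter, or none, is expected. The step expected here is a number 0.10 lower from compound 2 to compound 4 (within the scatter). Compound 4 is therefore expected to reach 0.5 in this assay, estimated between 0.3 and 0.7.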

Compound 4, intrinsic activity: the largest response reached, as a fraction of the reference agonist's: 0.4
Estimate against measurement, compound 4: 0.10 above; measured number inside the range.
By their numbers in this assay, from the lowest: compounds 3 and 4 (each within the scatter of the next); then compounds 2 and 1 (each within the scatter of the next).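

At this aromatic carbon of the shared core, bromo also lowers the maximal response in this assay, with a number 0.20 lower from compound 2 to compound 4 (beyond the scatter), matching the earlier a number 0.20 lower from compound 2 to compound 3 (beyond the scatter). Bromo and 1-methylethenyl are not separated, with no change at the digits printed from compound 3 to compound 4 (within the scatter), so two unlike entering groups give the same outcome and compound 2 stands apart from both. No evidence is available to explain this result.

As far as these compounds go, whether the higher value of compound 2 depends on the oxygen link or on the three-membered ring remains open. Methoxy and cyclopropyl at this carbon would separate the two, and an amine would test a different linking atom.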